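The source may report more compounds than this note shows. Statements on the series, on what has been measured and on what is new or still open speak of the compounds shown alone.

Working notes on an ADME assay on microsomes from liver (Mus musculus) for metabolic stability, read by LC-MS, with a stated time of 30 min, tested at 1 uM; a lower number here means that less of the compound is left, a higher number that more of the compound is left. Three compounds share one core and differ in the aryl group on the sulfonyl sulfur: compound 1 (`O=C(NCc1ccc(S(=O)(=O)c2cccc(C(F)(F)F)c2)cc1)c1cc2cnccc2[nH]1`) gives 49%, compound 2 (`O=C(NCc1ccc(S(=O)(=O)c2cc(F)cc(F)c2)cc1)c1cc2cnccc2[nH]1`) gives 63%, and compound 3 (`O=C(NCc1ccc(S(=O)(=O)c2ccccc2)cc1)c1cc2cnccc2[nH]1`) gives 54%. Compound 3 stands within the scatter of both others, with a number 5 percentage points higher from compound 1 to compound 3 (within the scatter) and a number 9 percentage points lower from compound 2 to compound 3 (within the scatter). Only a number 14 percentage points higher from compound 1 to compound 2 (beyond the scatter) exceeds the scatter, and that step is modest.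

The next entry is compound 4 (`Cc1cccc(S(=O)(=O)c2ccc(CNC(=O)c3cc4cnccc4[nH]3)cc2)c1`). Its difference from compound 3 is methyl in place of hydrogen on an aromatic carbon, meta to a large group. Going by the values given here, no measured step makes this exact change. The closest comparison is the exchange of hydrogen and trifluoromethyl on an aromatic carbon, where a number 5 percentage points higher from compound 1 to compound 3 (within the scatter) stays within the scatter. The exchange of phenyl and 3,5-difluorophenyl also stays within it, at a number 9 percentage points lower from compound 2 to compound 3 (within the scatter). Neither step points to a large effect from a single substituent on this ring, so no step beyond the scatter is expected. The estimated step is a number 4 percentage points lower from compound 3 to compound 4 (within the scatter), which is expected to fall within the scatter. Compound 4 is estimated at 50%, with an expected range of 37% to 62%.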

Compound 4, percent of the compound remaining: 32%
The estimate for compound 4 lay 18 percentage points above the measured number; the whole stated range lies above it.
By their numbers in this assay, from the lowest: compound 4; then compounds 1, 3 and 2 (each within the scatter of the next, the first and the last beyond it).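

In this assay, a single methyl at this place, meta to a large group, gives a number 22 percentage points lower from compound 3 to compound 4 (beyond the scatter), a larger change than any step among compounds 1, 2 and 3. The lower number does not follow from substitution on this ring in general: compound 1 with trifluoromethyl and compound 2 with two fluorines both stay within the scatter of the unsubstituted compound 3, and both go against such a reading, as a number 17 percentage points lower from compound 1 to compound 4 (beyond the scatter) and a number 31 percentage points lower from compound 2 to compound 4 (beyond the scatter) show, each beyond the scatter and the second of them large. So the drop so far belongs to methyl alone among the groups shown at this place, and nothing available here accounts for it.

The compounds shown leave open whether an ethyl, methoxy or hydroxymethyl group at this place would sit with compound 4 or with compounds 1, 2 and 3. They also leave open whether a methyl group elsewhere on this ring would give a step of similar size, and so whether the change depends on the place or on the group.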